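A Methoxy for Iodo Swap on the Benzamide

A few compounds are considered here, and "the series" means these few. Any claim that something is new, unique, unknown or untested is made for them only; others in the source may bear on it.

Two members of this series have been measured in a functional assay on MKN-74 cells (Homo sapiens) for antiproliferative activity, with a stated time of 24 h; on this read-out higher numbers stand for weaker inhibition and lower numbers for stronger inhibition. Compound 1 `COc1ccccc1C(=O)Nc1sc2c(c1C(N)=O)CCN(C(=S)Nc1ccccc1Cl)C2` gives 20500 nM. Compound 2 `COc1ccccc1NC(=S)N1CCc2c(sc(NC(=O)c3ccccc3I)c2C(N)=O)C1` gives 41800 nM, which is the higher of the two numbers, and the gap between compound 1 and compound 2 is beyond the usual scatter. Compound 1 and compound 2 differ in more than one place, so no single step can be read from this pair.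

Compound 3 `COc1ccccc1NC(=S)N1CCc2c(sc(NC(=O)c3ccccc3OC)c2C(N)=O)C1` has not yet been tested. It is obtained from compound 2 by a single change, (methoxy in place of iodo on an aromatic carbon). Among the measured compounds shown here, no measured pair in this set isolates that change, so its size is unknown. Given that compound 2 gives 41800 nM and compound 1, which also carries the methoxy group on that ring, gives 20500 nM, a modest move toward a lower number seems the more likely outcome, though a step within the scatter would not be surprising. Compound 3 is therefore expected to give 26000 nM in this assay, with a range from 11000 nM to 60000 nM, a step of a 1.6-fold lower number from compound 2 to compound 3 (0.21 log units; within the scatter) from compound 2.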

Compound 3, half-maximal inhibitory concentration: > 50000 nM
Compound 3: a limit, no number (the forecaster's own chance of this, stated with the estimate: 15%); middle value at least 1.9-fold (0.28 log units) away from the limit.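

In this assay compound 3 reaches a limit of the assay and not a number: the limit of > 50000 nM in this assay, at which 1 of the 3 values shown sits.

Putting methoxy in place of iodo, on an aromatic carbon ortho to a large group, gives an at least 1.1-fold higher number from compound 2 to compound 3 (0.07 log units; that floor lies within the scatter), so this change brought no move toward a lower number, while the floor of the step is too small to establish a real rise. With the methoxy group held on that ring, the change of chloro to methoxy on the other aromatic ring gives an at least 2.4-fold higher number from compound 1 to compound 3 (0.38 log units; beyond the scatter), the first single change in this set whose size is shown to pass the scatter, and it places the larger difference at the chloro site and not at the iodo site.

From the compounds shown here alone, how far compound 3 lies past the limit remains unknown, so both steps are known only as floors. Also open, going by these compounds, is whether an amine, a carboxylic acid or a longer alkoxy chain in place of the iodo group, or a bromo group in place of the chloro group, would give a lower number in this assay.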